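A few compounds are considered here, and "the series" means these few. Any claim that something is new, unique, unknown or untested is made for them only; others in the source may bear on it.

Compound 1: `C=C1C[C@@H]2OC(=O)C3=CCC[C@H]4[C@]15C[C@H](c1ccoc1)O[C@H]5OC(=O)[C@]324` — 9420 nM
Compound 2: `C=C1CC[C@]23C(C(=O)OC)=CCC[C@H]2[C@]12C[C@H](c1ccoc1)O[C@H]2O[C@@H]3O` — >= 10000 nM

In a functional assay on HL-60 cells (Homo sapiens) for cytotoxicity, read by MTT assay, with a stated time of 72 h (on this read-out lower numbers stand for stronger inhibition and higher numbers for weaker inhibition), compound 1 gives 9420 nM. For compound 2 the read-out is not a number but a limit, >= 10000 nM, which is the limit of >= 10000 nM in this assay, at which 1 of the 2 values shown sits. So compound 2 stands at the edge of what this assay can report, and its true value is not pinned down.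

Compound 3, `C=C1CC[C@]23C(C(=O)OC)=CCC[C@H]2[C@]12C[C@H](c1ccoc1)O[C@H]2O[C@H]3O`, has not been measured. It differs from compound 2 in a single respect: the two compounds have the same atoms and bonds and differ only in configuration as drawn: 1 of 6 stereo elements differ; a stereocentre at a saturated ring carbon is drawn S in compound 2 and R in compound 3. For the measured compounds named here, no step between two measured compounds is available for comparison, so the data give no measured guide to the size of such a change. The step that the limit leaves unreadable from compound 2 to compound 3 is expected to be none beyond the usual scatter. Compound 3 is therefore expected to give about 15000 nM, with a plausible range from 7000 nM to 40000 nM, and a limit rather than a number is the more likely outcome for compound 3.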

Compound 3, half-maximal inhibitory concentration: >= 10000 nM
Compound 3 ended at the assay's limit; the forecaster's own chance of this, stated with the estimate: 75%; the middle value lies beyond the limit too.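

No step can be read between compound 2 and compound 3: in this assay each gives a limit and not a number. The compounds shown leave open whether the different configuration at the saturated ring carbon changes the read-out at all.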